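A thiocarbonyl in place of the carbamate carbonyl

A few compounds are considered here, and "the series" means these few. Any claim that something is new, unique, unknown or untested is made for them only; others in the source may bear on it.

Three compounds share one core and differ only in the group on the ring amine nitrogen. Compound 1 `Cc1nc(S(C)(=O)=O)ccc1Oc1ncnc(OC2CCN(C(=O)OC(C)C)CC2)c1F` gives 21 nM in a functional assay on isolated protein for inhibition of Glucose-dependent insulinotropic receptor (Homo sapiens), read by HTRF and cAMP accumulation; a lower number here means that less compound is needed, a higher number that more compound is needed for the effect. Compound 2 `Cc1nc(S(C)(=O)=O)ccc1Oc1ncnc(OC2CCN(C(=O)O[C@H](C)C(F)(F)F)CC2)c1F` gives 9.2 nM, and compound 3 `Cc1nc(S(C)(=O)=O)ccc1Oc1ncnc(OC2CCN(C(=O)SC3CCC3)CC2)c1F` gives 8.51 nM. Compound 2 thus stands second highest of the three numbers, close to compound 3 and apart from compound 1: a 2.3-fold lower number from compound 1 to compound 2 (0.36 log units; beyond the scatter), while a 1.1-fold lower number from compound 2 to compound 3 (0.03 log units; within the scatter).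

Compound 4 `Cc1nc(S(C)(=O)=O)ccc1Oc1ncnc(OC2CCN(C(=S)OC(C)C)CC2)c1F` is unmeasured. The change from compound 2 is a group of 6 heavy atoms (4 carbon, 1 oxygen, 1 sulfur; no ring) in place of a group of 9 heavy atoms (4 carbon, 2 oxygen, 3 fluorine; no ring), on an amine nitrogen in a ring. Among the compounds with values here, two measured steps bear on it: the gain from compound 1 to compound 2 came with the trifluoromethyl group, which compound 4 gives up again, and compound 3 shows that a sulfur in this group can sit with a low number. Within the data shown here, no measured pair shows a carbonyl exchanged for a thiocarbonyl, so that part of the step is untested. On balance a modest rise in this assay is expected: a 2.2-fold higher number from compound 2 to compound 4 (0.34 log units; beyond the scatter).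

Compound 4 is therefore estimated at 20 nM, with a range from 8 nM to 50 nM.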

Compound 4, half-maximal effective concentration: 69.9 nM
The estimate for compound 4 lay 3.5-fold (0.54 log units) below the measured number; the measured number lies above the stated range.
By their numbers in this assay, from the lowest: compounds 3 and 2 (each within the scatter of the next); then compound 1; then compound 4.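

Within the data shown here, with the isopropoxy group held fixed, a thiocarbonyl in place of the carbonyl raises the number in this assay (so a 3.3-fold higher number from compound 1 to compound 4 (0.52 log units; beyond the scatter)), which is the one step here that isolates this exchange on the amine nitrogen in a ring. Sulfur alone therefore does not go with a low number at this position: compound 3 carries it as the link to the carbonyl carbon, whereas compound 4 carries it double-bonded and has the highest number of the four (with an 8.2-fold higher number from compound 3 to compound 4 (0.91 log units; beyond the scatter) and a 7.6-fold higher number from compound 2 to compound 4 (0.88 log units; beyond the scatter)). Nothing available here gives a reason for this rise.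

On these data alone, whether the thiocarbonyl exchange has the same size with 1-(trifluoromethyl)ethoxy or cyclobutylsulfanyl on the same carbon stays open. Also open, as far as these compounds go, is how a dimethylamino group on that carbon would compare.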